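Purine ribosides: varying the group on the methylene arm

The compounds below may be only part of what the source reports. "The series", "measured", "known", "first", "only" and "open" are said of these compounds alone.

Compound 2 `OC[C@H]1O[C@@H](n2cnc3c(Cn4ccc5ccccc54)ncnc32)[C@H](O)[C@@H]1O` gives 1960 nM in a functional assay on CCRF-CEM cells (Homo sapiens) for inhibition, read by XTT assay, with a stated time of 72 h (a lower number here means a stronger inhibitor, a higher number a weaker inhibitor), the second highest of the three numbers measured. Compound 1 `[N-]=[N+]=NCc1ncnc2c1ncn2[C@@H]1O[C@H](CO)[C@@H](O)[C@H]1O` gives 340 nM, and compound 3 `OC[C@H]1O[C@@H](n2cnc3c(COc4ccccn4)ncnc32)[C@H](O)[C@@H]1O` gives 10800 nM. Compound 4 `CSCc1ncnc2c1ncn2[C@@H]1O[C@H](CO)[C@@H](O)[C@H]1O` differs from compound 2 by methylsulfanyl in place of 1H-indol-1-yl on a saturated chain carbon bound to an aromatic carbon. The relevant step is a 5.8-fold higher number from compound 1 to compound 2 (0.76 log units; beyond the scatter), showing that a group with no ring on that carbon gives a lower number than the indolyl; a 32-fold higher number from compound 1 to compound 3 (1.50 log units; beyond the scatter) and a 5.5-fold higher number from compound 2 to compound 3 (0.74 log units; beyond the scatter) show that the group on that carbon moves the result widely. Since methylsulfanyl, like azido, has no ring, compound 4 is expected closer to compound 1 than to compound 2, a lower number in this assay. Compound 4 is expected at 500 nM, within 120 nM to 2500 nM. This corresponds to an expected 3.9-fold lower number from compound 2 to compound 4 (0.59 log units; beyond the scatter).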

Compound 4, half-maximal inhibitory concentration: 3200 nM
Compound 4: middle estimate off by 6.4-fold (0.81 log units), on the low side, and the stated range ends below it.
By their numbers in this assay, from the lowest: compound 1; then compounds 2 and 4 (each within the scatter of the next); then compound 3.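

In this assay, having no ring on that carbon does not by itself give a low number: a 9.4-fold higher number from compound 1 to compound 4 (0.97 log units; beyond the scatter) separates the two ringless groups, azido and methylsulfanyl, whereas a 1.6-fold higher number from compound 2 to compound 4 (0.21 log units; within the scatter) places methylsulfanyl level with 1H-indol-1-yl. The step of a 3.4-fold lower number from compound 3 to compound 4 (0.53 log units; beyond the scatter) shows that (pyridin-2-yl)oxy remains apart from methylsulfanyl, so the presence of a ring does not sort these groups either. No supporting evidence accounts for the separation of azido from methylsulfanyl. On these data alone, it remains open whether an amine, a carboxylic acid or a longer chain on that carbon would sit nearer compound 1 or compound 4.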